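Swapping the outer ring on compound 2: fluorine for methyl

The source may report more compounds than this note shows. Statements on the series, on what has been measured and on what is new or still open speak of the compounds shown alone.

Compound 2 `Cc1ccc(NC(=O)Nc2cc(C)nc3ccccc23)cc1` has the lowest number of the three measured compounds in a physicochemical assay for solubility, at pH 7.4 (on this read-out lower numbers stand for lower solubility and higher numbers for higher solubility), giving 1300 nM. Compound 1 `Cc1cc(NC(=O)Nc2ccc(C(=O)O)cc2)c2ccccc2n1` gives 9300 nM and compound 3 `CC(=O)c1ccc(NC(=O)Nc2cc(C)nc3ccccc23)cc1` gives 3800 nM; the steps are a 7.2-fold lower number from compound 1 to compound 2 (0.85 log units; beyond the scatter) and a 2.9-fold higher number from compound 2 to compound 3 (0.47 log units; beyond the scatter). Compound 4 `Cc1cc(NC(=O)Nc2cccc(F)c2)c2ccccc2n1` differs from compound 2 in one place: 3-fluorophenyl in place of 4-methylphenyl on an amide-type nitrogen. Within the data shown here, the measured steps alter the 4-methylphenyl group that now leaves, not the whole ring, so none matches this change; they show only that changes on this ring moved this assay by modest amounts. Compound 4 is therefore expected to stay close to compound 2, with a step of a 1.4-fold higher number from compound 2 to compound 4 (0.14 log units; within the scatter) as the estimate. The estimated value for compound 4 is 1800 nM, within 700 nM to 4500 nM.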

Compound 4, solubility: 100 nM
Estimate against measurement, compound 4: 18-fold (1.26 log units) above; measured number outside the range, below it.
By their numbers in this assay, from the lowest: compound 4; then compound 2; then compound 3; then compound 1.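

Exchanging the whole outer ring moves this assay much further than the earlier changes to its substituent suggested: 3-fluorophenyl in place of 4-methylphenyl on the amide-type nitrogen gives a 13-fold lower number from compound 2 to compound 4 (1.11 log units; beyond the scatter), a large step. This happens even though both groups have the same heavy-atom count and neither has hydrogen-bond donors, hydrogen-bond acceptors or a net charge. Nothing available explains the drop.

Among these compounds, the single step changes both the substituent and its printed ring position, so it remains open which of these matters. As far as these compounds go, it is also open how an amine or a methoxy group on this ring would read in this assay.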